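Chloro on the Second Phenyl: Compound 2 to Compound 4

A few compounds are considered here, and "the series" means these few. Any claim that something is new, unique, unknown or untested is made for them only; others in the source may bear on it.

Compound 2 `Cc1nc(-c2ccccc2)sc1C(=O)CSc1nc(N)c(C#N)c(-c2ccc(Cl)cc2)n1` stands highest of the three numbers in a functional assay on U-87MG ATCC cells for antiproliferative activity against U-87 MG (Homo sapiens), read by MTT assay, with a stated time of 48 h, tested at 50 uM; a higher number here means a weaker effect of the compound at the concentration tested, a lower number a stronger effect: compound 2 gives 44.3%. Its nearest neighbour is compound 3 `Cc1nc(-c2ccccc2)sc1C(=O)CSc1nc(N)c(C#N)c(-c2ccccc2)n1`, which in this assay gives 26.3%; the furthest is compound 1 `COc1ccc(-c2nc(C)c(C(=O)CSc3nc(N)c(C#N)c(-c4ccc(Cl)cc4)n3)s2)cc1`, which in this assay gives 23.1%. The two measured steps are a number 21.2 percentage points higher from compound 1 to compound 2 (beyond the scatter) and a number 18 percentage points lower from compound 2 to compound 3 (beyond the scatter).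

Compound 4 `Cc1nc(-c2ccc(Cl)cc2)sc1C(=O)CSc1nc(N)c(C#N)c(-c2ccc(Cl)cc2)n1` differs from compound 2 by chloro in place of hydrogen on an aromatic carbon. Both measured steps bear on it, though from different sides. The step to compound 1 shows that a group at this same place, para to a large group, goes with a lower number; the step to compound 3 shows that a chloro on the other phenyl goes with a higher number. The two pull in opposite directions, and the expectation for compound 4 is therefore a modest step down, a number 12.3 percentage points lower from compound 2 to compound 4 (beyond the scatter), with wide uncertainty. Compound 4 is estimated at 32%, in the range 15% to 50%.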

Compound 4, a percentage reported as activity, at one concentration (the size of the read-out at that concentration, not a potency): 15.5%
Compound 4: the middle estimate sits 16.5 percentage points above what was measured, and the stated range covers the measured number.
By their numbers in this assay, from the lowest: compounds 4, 1 and 3 (each within the scatter of the next, the first and the last beyond it); then compound 2.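

In this assay the change from phenyl to 4-chlorophenyl gives a number 28.8 percentage points lower from compound 2 to compound 4 (beyond the scatter) and so a lower number at this place no longer rests on methoxy alone, while a number 7.6 percentage points lower from compound 1 to compound 4 (within the scatter) leaves chloro and methoxy here without an order. Removing a chloro from the other phenyl gives a number 18 percentage points lower from compound 2 to compound 3 (beyond the scatter) so the same exchange runs in opposite directions on the two phenyl rings of this small set. No measurement at hand gives a reason for that difference.

As far as these compounds go, whether a lower number also goes with an amine, a carboxylic acid or a longer chain para to the large group remains open. Also open, from the compounds shown here alone, is how far the step seen here carries over to compounds with hydrogen in place of the chloro on the other phenyl.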